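A few compounds are considered here, and "the series" means these few. Any claim that something is new, unique, unknown or untested is made for them only; others in the source may bear on it.

Compound 1 `O=[N+]([O-])c1ccccc1-c1nnc(-c2ccc(-n3cccc3)cc2)o1` was examined in an ADME assay on A549 cells (Homo sapiens) for cytotoxicity, read by MTT assay, with a stated time of 72 h; on this read-out lower numbers stand for stronger inhibition and higher numbers for weaker inhibition. In this assay compound 1 gives 267000 nM. Compound 2 `CC(=O)NNC(=O)c1ccc(-n2c(C)ccc2C)cc1` gives 180000 nM in this assay. Compound 1 has the higher of these two numbers, yet its gap to compound 2 lies within the usual scatter, so the two stand level. Compound 3 `Cc1ccc(C)n1-c1ccc(C(=O)NN=C(c2ccccc2)c2ccccc2)cc1` gives "not determined" (no result reported) in this assay, so no result was reported for it. Compound 4 `c1ccc(-c2nnc(-c3ccc(-n4cccc4)cc3)o2)cc1` differs from compound 1 by hydrogen in place of nitro on an aromatic carbon. Within the data shown here, no pair of measured compounds shows what this exchange does to the number, so the data give no direction for it. The step from compound 1 to compound 4 is expected to be a 1.1-fold lower number from compound 1 to compound 4 (0.03 log units; within the scatter), nothing beyond the scatter. Compound 4 is therefore expected to give 250000 nM in this assay, in a range from 80000 nM to 700000 nM.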

Compound 4, half-maximal inhibitory concentration: 256000 nM
For compound 4 the middle estimate is 1.0-fold (0.01 log units) below the measured one, and the stated range covers the measured number.
By their numbers in this assay, from the lowest: compounds 2, 4 and 1 (each within the scatter of the next).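

Hydrogen in place of nitro, on an aromatic carbon ortho to a large group, gives a 1.0-fold lower number from compound 1 to compound 4 (0.02 log units; within the scatter) in this assay, so the two compounds stand level. Among these compounds, this pair gives the first direct reading of this exchange, and at this place on this core the nitro group makes no difference beyond the scatter. Nothing measured here offers a reason for this result. From the compounds shown here alone, whether an amine or a carboxylic acid at this place would also stand level with compound 4 remains open. Also open, going by these compounds, is whether the same exchange would read alike on a different core.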